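Trimethoxy Variant of Compound 2: Cytotoxicity Outlook

The compounds below may be only part of what the source reports. "The series", "measured", "known", "first", "only" and "open" are said of these compounds alone.

Compound 1 `COc1ccc([C@H]2CC(C)(O)[C@@H]3CC[C@@H](C)C[C@H]3O2)c(OC)c1`: in an ADME assay on MDCK cells (Canis lupus familiaris) for cytotoxicity, read by MTT assay, with a stated time of 48 h (on this read-out lower numbers stand for higher toxicity in this test and higher numbers for lower toxicity in this test), compound 1 returns only an assay limit, > 937000 nM.
Compound 2 `COc1ccc([C@H]2CC(C)(F)[C@@H]3CC[C@@H](C)C[C@H]3O2)c(OC)c1`: compound 2 gives 379000 nM.
Compound 3 `COc1ccc([C@H]2CC(C)(F)[C@@H]3CC[C@@H](C)C[C@H]3O2)c(OC)c1OC`: compound 3 gives 133000 nM.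

Compound 2 holds the highest of the two numbers; compound 3 sits a modest distance below it, and compound 1 is known only as a limit (the limit of > 937000 nM in this assay, at which 1 of the 3 values shown sits). Compound 4 `COc1cc(OC)c([C@H]2CC(C)(F)[C@@H]3CC[C@@H](C)C[C@H]3O2)cc1OC` differs from compound 2 by methoxy in place of hydrogen on an aromatic carbon. Within the data shown here, two measured steps bear on this: an at least 2.4-fold lower number from compound 1 to compound 2 (0.39 log units; beyond the scatter) and, closer in kind, a 2.8-fold lower number from compound 2 to compound 3 (0.45 log units; beyond the scatter), where a methoxy likewise entered an aromatic carbon. A step of similar size in the same direction is therefore expected for compound 4, a 2.5-fold lower number from compound 2 to compound 4 (0.40 log units; beyond the scatter). Compound 4 is estimated at 150000 nM, with a range from 60000 nM to 400000 nM.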

Compound 4, half-maximal cytotoxic concentration: 78000 nM
The estimate for compound 4 lay 1.9-fold (0.28 log units) above the measured number, within the range that was stated.
By their numbers in this assay, from the lowest: compounds 4 and 3 (each within the scatter of the next); then compound 2. At a limit, above all of these: compound 1.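

Methoxy in place of hydrogen on the aromatic carbon ortho to a methoxy group, meta to a large group and para to a methoxy group gives a 4.9-fold lower number from compound 2 to compound 4 (0.69 log units; beyond the scatter) in this assay. The lowering is therefore not confined to the single placement seen in a 2.8-fold lower number from compound 2 to compound 3 (0.45 log units; beyond the scatter), and compound 3 and compound 4 stay within the scatter of each other, so these two placements are not separated. No measured property shown here accounts for the step.

Open, as far as these compounds go, is whether an amine or a carboxylic acid on this aromatic carbon would shift the number as methoxy does. Also open, from the compounds shown here alone, is whether ethoxy, a longer chain, would do the same.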